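Swapping one aromatic ring for another on a brominated core

This account rests on a few compounds, and the source may have more. Where it says the series, first, only, none or still open, it means among the compounds named here.

Compound 1 `COc1cccc(C(O)CCn2nc3c(Br)c(Br)c(Br)c(Br)c3n2)c1` was tested in a functional assay on MCF7 cells (Homo sapiens) for antiproliferative activity, read by MTT assay, with a stated time of 48 h, tested at 50 uM (a lower number here means a stronger effect, a higher number a weaker effect of the compound at the concentration tested), where compound 1 gives 20%. Compound 2 `C[C@@H](O)CCn1nc2c(Br)c(Br)c(Br)c(Br)c2n1` gives 64% in this assay. Of the two numbers, compound 1 shows the lower one, which here means the stronger effect, and the gap to compound 2 lies beyond the usual scatter of such measurements. Compound 3 `OC(CCn1nc2c(Br)c(Br)c(Br)c(Br)c2n1)c1ccc(Cl)cc1` has not yet been measured. It differs from compound 1 in one place: 4-chlorophenyl in place of 3-methoxyphenyl on a saturated chain carbon bound to an oxygen on a saturated carbon and a saturated chain carbon. An aromatic ring therefore stays on the saturated chain carbon, only its substituent changes. For the measured compounds named here, no measured pair shows an exchange of this kind, so the data give no size for such a step. The aromatic-ring compound 1 stands at 20%, far from compound 2, which suggests the aromatic ring carries much of the effect. A step within the scatter is expected, a number 5 percentage points higher from compound 1 to compound 3 (within the scatter), in no sure direction. Compound 3 is therefore estimated at 25%, with a likely range from 8% to 50%.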

Compound 3, a percentage reported as activity, at one concentration (the size of the read-out at that concentration, not a potency): 9%
Estimate against measurement, compound 3: 16 percentage points above, within the range that was stated.
By their numbers in this assay, from the lowest: compound 3; then compound 1; then compound 2.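

The ring on this carbon does more than simply be present: in this assay, putting 4-chlorophenyl in place of 3-methoxyphenyl on the saturated chain carbon bound to an oxygen gives a number 11 percentage points lower from compound 1 to compound 3 (beyond the scatter). For the compounds shown here, this modest step is the first measured size for an exchange of one substituted aromatic ring for another at this position, and since a lower number means a stronger effect, it favours the 4-chlorophenyl compound at the concentration tested. The data offer no independent measurement that could say why the read-out moves with this exchange.

This single pair changes the substituent and the ring position it occupies in one step, so 3-chlorophenyl and 4-methoxyphenyl on the same carbon would be needed to tell apart the contribution of each. Also open, going by these compounds, is how the read-out would respond to a phenyl ring with no substituent, to a ring bearing an amine or a carboxylic acid, or to a longer chain linking this carbon to the shared core.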